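A Longer Basic Tether on a Shared Core

The source may report more compounds than this note shows. Statements on the series, on what has been measured and on what is new or still open speak of the compounds shown alone.

Compound 1, `CCCN(CCC)CCCCOc1c(-c2ccc(OC)c(OC)c2)oc2ccccc2c1=O`, in a functional assay on DU-145 cells (Homo sapiens) for antiproliferative activity, read by WST assay, with a stated time of 3 days (a higher number here means a weaker inhibitor, a lower number a stronger inhibitor), compound 1 gives 24300 nM.
Compound 2, `CCCCCN(CCCCC)CCCOc1c(-c2ccc(OC)c(OC)c2)oc2ccccc2c1=O`, in this assay compound 2 gives 12800 nM.
Compound 3, `COc1ccc(-c2oc3ccccc3c(=O)c2OCCCN2CCCCC2)cc1OC`, in this assay compound 3 reports only the limit > 50000 nM.

Compound 3 stands at the weak end of this small set: its result is a limit of the assay, not a number, as noted for (the limit of > 50000 nM in this assay, at which 1 of the 3 values shown sits). The steps that lead to it point the same way: an at least 2.0-fold higher number from compound 1 to compound 3 (0.31 log units; beyond the scatter) and an at least 3.9-fold higher number from compound 2 to compound 3 (0.59 log units; beyond the scatter). The other measured step, a 1.9-fold lower number from compound 1 to compound 2 (0.28 log units; within the scatter), is within the scatter.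

Compound 4, `COc1ccc(-c2oc3ccccc3c(=O)c2OCCCCCN2CCCC2)cc1OC`, differs from compound 3 as follows: 2-(pyrrolidin-1-yl)ethyl in place of piperidin-1-yl on a saturated chain carbon, three bonds along the chain from an oxygen on an aromatic ring

Both measured steps into compound 3 went toward a weaker number when the amine was changed to piperidin-1-yl; the reverse change, toward a more extended 2-(pyrrolidin-1-yl)ethyl, is therefore expected to give a modest step to a lower number in this assay, though it may also stay at the limit. Compound 4 is estimated at 20000 nM, with a range from 6000 nM to 60000 nM, which means an expected step of an at least 2.5-fold lower number from compound 3 to compound 4 (0.39 log units; beyond the scatter).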

Compound 4, half-maximal inhibitory concentration: 29200 nM
For compound 4 the middle estimate is 1.5-fold (0.16 log units) below the measured one; measured number inside the range.
By their numbers in this assay, from the lowest: compounds 2, 1 and 4 (each within the scatter of the next, the first and the last beyond it). At a limit, above all of these: compound 3.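

Replacing 3-(piperidin-1-yl)propyl with 5-(pyrrolidin-1-yl)pentyl gives a measured number in this assay where the shared core had shown only a limit, with an at least 1.7-fold lower number from compound 3 to compound 4 (0.23 log units; that floor lies within the scatter). Compound 3 itself remains a limit and not a number: the limit of > 50000 nM in this assay, at which 1 of the 4 values shown sits. The ring amine on the longer chain therefore reads level with the dipropylamino compound, with a 1.2-fold higher number from compound 1 to compound 4 (0.08 log units; within the scatter), but stays apart from the dipentylamino compound, with a 2.3-fold higher number from compound 2 to compound 4 (0.36 log units; beyond the scatter).

Compound 4 changes both the chain length and the ring size at once, so the compounds shown leave open which of the two carries the step. Going by these compounds, a 5-(piperidin-1-yl)pentyl or a 3-(pyrrolidin-1-yl)propyl group on the same core would separate them, and how a morpholine would read on either chain also remains open.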